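This account rests on a few compounds, and the source may have more. Where it says the series, first, only, none or still open, it means among the compounds named here.

Working notes on the series in a functional assay on PC-3 cells (Homo sapiens) for inhibition, read by MTT assay, with a stated time of 48 h; a lower number here means a stronger inhibitor, a higher number a weaker inhibitor. Compound 1 `COc1ccc(-n2c(SC)nnc2-c2cc(OC)c(OC)c(OC)c2)cc1` reads > 60000 nM, which is a limit of the assay and not a number. Compound 2 `COc1ccc(-n2c(SCC(=O)c3ccc(F)cc3)nnc2-c2cc(OC)c(OC)c(OC)c2)cc1` gives 58300 nM, and compound 3 `COc1ccc(-n2c(SCC(=O)C3CC3)nnc2-c2cc(OC)c(OC)c(OC)c2)cc1` gives 37200 nM, the lower of the two numbers, though the gap is a 1.6-fold lower number from compound 2 to compound 3 (0.20 log units; within the scatter). The floors on the steps out of compound 1, an at least 1.0-fold lower number from compound 1 to compound 2 (0.01 log units; that floor lies within the scatter) and an at least 1.6-fold lower number from compound 1 to compound 3 (0.20 log units; that floor lies within the scatter), also stay within the scatter.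

Compound 4 `COc1ccc(NC(=O)CSc2nnc(-c3cc(OC)c(OC)c(OC)c3)n2-c2ccc(OC)cc2)cc1` differs from compound 3 by (4-methoxyphenyl)amino in place of cyclopropyl on a carbonyl carbon. Within the data shown here, the closest precedent is the exchange on that same carbonyl carbon, a 1.6-fold lower number from compound 2 to compound 3 (0.20 log units; within the scatter), so no step beyond the scatter is expected. The expected step is a 1.2-fold lower number from compound 3 to compound 4 (0.09 log units; within the scatter). For compound 4 the estimated value is 30000 nM, with an expected range of 8000 nM to 70000 nM.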

Compound 4, half-maximal inhibitory concentration: 25800 nM
Compound 4: middle estimate off by 1.2-fold (0.07 log units), on the high side; the range from low to high includes it.
By their numbers in this assay, from the lowest: compounds 4, 3 and 2 (each within the scatter of the next, the first and the last beyond it). At a limit, above all of these: compound 1.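

In this assay, among these compounds, (4-methoxyphenyl)amino on the carbonyl carbon gives the first step between two numbers that lies beyond the scatter, a 2.3-fold lower number from compound 2 to compound 4 (0.35 log units; beyond the scatter) (modest), yet a 1.4-fold lower number from compound 3 to compound 4 (0.16 log units; within the scatter) stays within it. The step from the hydrogen on the saturated chain carbon bound to a sulfur also clears the scatter: an at least 2.3-fold lower number from compound 1 to compound 4 (0.36 log units; beyond the scatter). Compound 1 stands at a limit, so that step is only a floor: the limit of > 60000 nM in this assay, at which 1 of the 4 values shown sits.

The amide hydrogen and the 4-methoxyphenyl ring enter together in compound 4, so their shares stay unseparated. Going by these compounds, how a dimethylamino group or a carboxylic acid on that carbonyl carbon would read stays open.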